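Benzyl para-substituent swap in indole hydrazide cytotoxicity series

The source may report more compounds than this note shows. Statements on the series, on what has been measured and on what is new or still open speak of the compounds shown alone.

Measured so far:
compound 1 `COc1ccc(Cn2cc(/C=N\NC(=O)c3c[nH]c4ccccc34)c3ccccc32)cc1` 41600 nM
compound 2 `COc1ccc(Cn2cc(/C=N\NC(=O)c3c[nH]c4ccccc34)c3cc(OC)ccc32)cc1` 30500 nM

In a functional assay on MIA PaCa-2 cells (Homo sapiens) for cytotoxicity (on this read-out lower numbers stand for stronger inhibition and higher numbers for weaker inhibition), compound 2 gives the lowest of the two numbers, yet compound 1 lies a 1.4-fold lower number from compound 1 to compound 2 (0.13 log units; within the scatter) from it, a gap within the scatter. Compound 3 `COc1ccc2c(c1)c(/C=N\NC(=O)c1c[nH]c3ccccc13)cn2Cc1ccc(Cl)cc1` differs from compound 2 by chloro in place of methoxy on an aromatic carbon. Going by the values given here, no measured step touches this position; the only step known concerns methoxy in place of hydrogen elsewhere. Nothing therefore points beyond the scatter, and compound 3 is expected near compound 2, with a 1.0-fold lower number from compound 2 to compound 3 (0.01 log units; within the scatter) as the estimated step. Compound 3 is estimated at 30000 nM, range 10000 nM to 90000 nM.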

Compound 3, half-maximal inhibitory concentration: 26700 nM
Estimate against measurement, compound 3: 1.1-fold (0.05 log units) above; low and high end bracket the measured number.
By their numbers in this assay, from the lowest: compounds 3, 2 and 1 (each within the scatter of the next).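

Going by these compounds alone, the 4-methoxybenzyl to 4-chlorobenzyl change is the first probe of this position, and in this assay it gives a 1.1-fold lower number from compound 2 to compound 3 (0.06 log units; within the scatter) as its step. Chloro and methoxy on this aromatic carbon therefore cannot be told apart on this read-out, so this position joins the methoxy on the core in showing no step beyond the scatter. No measurement bears on what lies behind this result. Going by these compounds, whether an amine or a carboxylic acid on this aromatic carbon would give a step beyond the scatter remains open. On these data alone, how chloro behaves on the core of compound 1 also remains open.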